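Macrocyclic aldehyde series: cytotoxicity working notes

The compounds below may be only part of what the source reports. "The series", "measured", "known", "first", "only" and "open" are said of these compounds alone.

Measured compounds:
compound 1, `CC(C)C[C@@H]1NC(=O)[C@@H](NC(=O)OCc2ccccc2)Cc2cn(nn2)CCCNC(=O)CC[C@@H](C=O)NC1=O`: > 100000 nM
compound 2, `CC(C)C[C@@H]1NC(=O)[C@@H](NC(=O)OCc2ccccc2)Cc2cn(nn2)CCCCCNC(=O)CC[C@@H](C=O)NC1=O`: > 100000 nM

In an ADME assay on HG23 cells (Homo sapiens) for cytotoxicity, with a stated time of 72 h (on this read-out higher numbers stand for lower toxicity in this test and lower numbers for higher toxicity in this test), compound 1 gives > 100000 nM, a limit of the assay rather than a number. In this assay compound 2 gives > 100000 nM, likewise only a limit. Compound 2 thus stands at the limit of > 100000 nM in this assay, at which 2 of the 2 values shown sit. Compound 3, `O=C[C@@H]1CCC(=O)NCCCCCn2cc(nn2)C[C@H](NC(=O)OCc2ccccc2)C(=O)N[C@@H](CC2CCCCC2)C(=O)N1`, is not yet measured; it differs from compound 2 by cyclohexyl in place of isopropyl on a saturated chain carbon bound to a saturated ring carbon. Going by the values given here, no step between measured compounds is available. Compound 3 is expected to show no step beyond the scatter, the estimated step being a number no higher from compound 2 to compound 3 (the limit leaves the size open). For compound 3 the expected value in this assay is 100000 nM, with a range from 50000 nM to 200000 nM.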

Compound 3, half-maximal cytotoxic concentration: > 100000 nM
Compound 3 ended at the assay's limit; the forecaster's own chance of this, stated with the estimate: 85%; the middle value lies on the limit itself.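

No step can be read from compound 2 to compound 3, since both values are only limits: the limit of > 100000 nM in this assay, at which 3 of the 3 values shown sit.
The compounds shown leave open whether cyclohexyl in place of isopropyl alters cytotoxicity, and at what concentration any of the three compounds becomes toxic.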